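The source may report more compounds than this note shows. Statements on the series, on what has been measured and on what is new or still open speak of the compounds shown alone.

Measured so far:

Compound 1 `CCC(C)C(=O)Nc1c(C(O)(C(F)(F)F)C(F)(F)F)ccc2ccccc12`; in an assay on LtK cells with ATP-sensitive inward rectifier potassium channel 11 (Homo sapiens) as the target (a higher number here means that more compound is needed for the effect, a lower number that less compound is needed), compound 1 gives 177000 nM.

Compound 2 `CC(C)OC(=O)Nc1c(C(O)(C(F)(F)F)C(F)(F)F)ccc2ccccc12`; in this assay compound 2 gives 1160 nM.

Within the data shown here, compound 2 has the lower of the two numbers; its only neighbour is compound 1, and the step between them, a 150-fold lower number from compound 1 to compound 2 (2.18 log units; beyond the scatter), shows how strongly the group on the carbonyl carbon can shift the result. Compound 3 `O=C(Nc1c(C(O)(C(F)(F)F)C(F)(F)F)ccc2ccccc12)c1ccc(Br)cc1` changes that same group again: 4-bromophenyl in place of isopropoxy on a carbonyl carbon. Among the measured compounds shown here, no measured step brings an aromatic ring into this position, so the earlier step only tells that the change could be large in either direction. A moderate rise in the number is expected, a 4.3-fold higher number from compound 2 to compound 3 (0.63 log units; beyond the scatter). Compound 3 is therefore estimated at 5000 nM, with a range from 400 nM to 60000 nM.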

Compound 3, half-maximal effective concentration: 47 nM
Compound 3: middle estimate off by 110-fold (2.03 log units), on the high side, outside the stated range (below it).
By their numbers in this assay, from the lowest: compound 3; then compound 2; then compound 1.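

In this assay, the largest drop so far comes from putting an aromatic ring on the carbonyl carbon: there is a 25-fold lower number from compound 2 to compound 3 (1.39 log units; beyond the scatter), and a 3800-fold lower number from compound 1 to compound 3 (3.58 log units; beyond the scatter). This one place therefore separates all three compounds clearly, with 4-bromophenyl giving the lowest number, isopropoxy the middle one and sec-butyl the highest. Nothing measured here explains why the number falls so far.

Going by these compounds, it remains open whether the bromine is needed or the ring alone is enough. A plain phenyl, a 4-chlorophenyl or a pyridine ring at this place could help settle that.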